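Two hydroxyphenyl groups on a shared core: moving one hydroxyl

The source may report more compounds than this note shows. Statements on the series, on what has been measured and on what is new or still open speak of the compounds shown alone.

Measured in a functional assay on HCT-15 cells (Homo sapiens) for inhibition; a higher number here means a weaker inhibitor, a lower number a stronger inhibitor:
Compound 1, `Oc1cccc(-c2cc(-c3ccccc3C(F)(F)F)cc(-c3cccc(O)c3)n2)c1`: 8150 nM
Compound 2, `Oc1ccc(-c2cc(-c3ccccc3C(F)(F)F)cc(-c3cccc(O)c3)n2)cc1`: 5740 nM
Compound 3, `Oc1ccc(-c2cc(-c3ccc(OC(F)(F)F)cc3)cc(-c3cccc(O)c3)n2)cc1`: 1380 nM

Compounds 1 and 2 differ in one place, (4-hydroxyphenyl in place of 3-hydroxyphenyl on an aromatic carbon), and the result was a 1.4-fold lower number from compound 1 to compound 2 (0.15 log units; within the scatter). Compound 3 has the lowest number of the three, and its distance from compounds 1 and 2 lies beyond the scatter; how its core differs from that of compound 1 is not broken down here.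

Compound 4, `Oc1ccc(-c2cc(-c3ccc(OC(F)(F)F)cc3)cc(-c3ccc(O)cc3)n2)cc1`, is not yet measured. It differs from compound 3 by 4-hydroxyphenyl in place of 3-hydroxyphenyl on an aromatic carbon. This is the same kind of change as from compound 1 to compound 2, though the surroundings differ: there the place was meta to a 2-(trifluoromethyl)phenyl group and meta to a 3-hydroxyphenyl group, here it is meta to a 4-hydroxyphenyl group and meta to a large group.

Because the earlier step was a 1.4-fold lower number from compound 1 to compound 2 (0.15 log units; within the scatter), only a small step is expected here too, estimated at a 1.3-fold lower number from compound 3 to compound 4 (0.10 log units; within the scatter). Compound 4 is therefore expected to give about 1100 nM, likely between 500 nM and 2500 nM.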

Compound 4, half-maximal inhibitory concentration: 13900 nM
The estimate for compound 4 lay 13-fold (1.10 log units) below the measured number, outside the stated range (above it).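

In this assay, replacing the 3-hydroxyphenyl group of compound 3 with a 4-hydroxyphenyl group gave a 10-fold higher number from compound 3 to compound 4 (1.00 log units; beyond the scatter), so on this core the change clearly weakens inhibition. Set beside the earlier step, the same change does not carry over from one core to the other with the same size, and a result on one core is therefore a poor guide to the other here: the same change on two cores in this assay, a 1.4-fold lower number (0.15 log units; within the scatter) from compound 1 to compound 2 and a 10-fold higher number (1.00 log units; beyond the scatter) from compound 3 to compound 4, 14-fold (1.16 log units) apart, beyond the scatter of two such steps This rests on only two pairs of compounds, and it shows that the outcome depends on the surrounding core, but not which feature of the core is responsible or how the change would behave on a third core.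

The compounds shown leave open what happens when the hydroxyl on the moved ring is replaced by another group, such as a methoxy group or an amine. They also leave open whether a 4-hydroxyphenyl group would cost as much on a core carrying a different substituent, such as a carboxylic acid.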